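The source may hold more compounds than are shown below. What is called first, only, known or untested is meant among the compounds shown, and "the series" means these compounds.

In an assay on HEK293 cells for positive allosteric modulation of metabotropic glutamate receptor 2 (Rattus norvegicus), read by thallium flux, with a stated time of 2.5 min (a lower number here means a smaller maximal response, a higher number a larger maximal response), compound 1, `CCC(=O)c1ccc(OCCCCOc2cc(C(=O)O)ccc2OC)c(C)c1O`, gives 72.6%. Compound 2, `COc1ccc(C(=O)O)cc1OCCCCOc1ccc(C(C)=O)c(O)c1C`, reaches 70.7% in this assay. The two share a core and differ in one place, (methyl in place of hydrogen on a saturated chain carbon bound to a carbonyl carbon); the change made a number 1.9 percentage points higher from compound 2 to compound 1 (within the scatter). Compound 3, `CCC(=O)c1ccc(OCCCCOc2ccc(F)c(C(=O)O)c2)c(C)c1O`, gives 66.6% in this assay. How the core of compound 3 differs from that of compound 2 is not broken down here; the two values lie within the scatter of each other.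

Compound 4, `Cc1c(OCCCCOc2ccc(F)c(C(=O)O)c2)ccc(C(=O)C(C)C)c1O`, has not been measured. Its difference from compound 3 is methyl in place of hydrogen on a saturated chain carbon bound to a carbonyl carbon and a saturated chain carbon. For the measured compounds named here, this is the same kind of change as the one from compound 2 to compound 1, but not the same: in the earlier pair the place is a saturated chain carbon bound to a carbonyl carbon, whereas here the place is a saturated chain carbon bound to a carbonyl carbon and a saturated chain carbon. Because the step of a number 1.9 percentage points higher from compound 2 to compound 1 (within the scatter) stayed within the scatter, a step of the same kind is expected to stay within it as well, so the estimated step is a number 1.4 percentage points higher from compound 3 to compound 4 (within the scatter). Compound 4 is therefore expected to reach about 68% in this assay, most likely between 56% and 80%.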

Compound 4, largest response reached (reported as percent of maximum), in percent of the reference or control that the assay uses: 74.1%
Beside the measured number, compound 4's estimate is 6.1 percentage points below it; the range from low to high includes it.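

In this assay, methyl in place of hydrogen on a saturated chain carbon bound to a carbonyl carbon and a saturated chain carbon gives a number 7.5 percentage points higher from compound 3 to compound 4 (within the scatter), and this step from propanoyl to isopropylcarbonyl stays inside the usual scatter. Set beside the earlier methyl step, the change carries over from one core to the other without a difference that can be told apart from scatter: the same change on two cores in this assay, a number 1.9 percentage points higher (within the scatter) from compound 2 to compound 1 and a number 7.5 percentage points higher (within the scatter) from compound 3 to compound 4, 5.6 percentage points apart, within the scatter of two such steps. This shows only that, in these two pairs, the added methyl leaves the maximal response within what repeated measurements would give; it does not show that the two steps are equal in size, that the two places are interchangeable, or that the same would hold on any further core.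

The compounds shown leave open what a longer acyl chain or a ring-bearing acyl group such as cyclopropylcarbonyl would do in this assay. They also leave open whether the result would hold with an amide or a tetrazole in place of the carboxylic acid.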